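The compounds below may be only part of what the source reports. "The series", "measured", "known", "first", "only" and "open" are said of these compounds alone.

Three compounds have been measured in a functional assay on PC-3 cells (Homo sapiens) for antiproliferative activity, read by MTT assay, with a stated time of 48 h; on this read-out higher numbers stand for weaker inhibition and lower numbers for stronger inhibition:

Compound 1, `O=C(/C=C\Nc1ccc(Cl)cc1)c1cn(-c2ccccc2)nc1-c1ccc(Cl)cc1`, gives 3890 nM.
Compound 2, `O=C(/C=C\Nc1ccc(C(F)(F)F)cc1)c1cn(-c2ccccc2)nc1-c1ccc(Cl)cc1`, reaches only the limit of the assay, > 50000 nM, and so has no number.
Compound 3, `O=C(/C=C\Nc1ccc(O)cc1)c1cn(-c2ccccc2)nc1-c1ccc(Cl)cc1`, gives 4430 nM.

Compound 3 therefore holds the higher of the two numbers, but its nearest neighbour is compound 1, and a 1.1-fold higher number from compound 1 to compound 3 (0.06 log units; within the scatter), so the two cannot be told apart. The one large effect seen so far sits on the ring carrying the amine: an at least 12-fold higher number from compound 1 to compound 2 (1.10 log units; beyond the scatter), and an at least 11-fold lower number from compound 2 to compound 3 (1.05 log units; beyond the scatter), where the limit of > 50000 nM in this assay, at which 1 of the 3 values shown sits, marks compound 2 as a limit rather than a number.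

Compound 4, `COc1ccc(-c2nn(-c3ccccc3)cc2C(=O)/C=C\Nc2ccc(O)cc2)cc1`, differs from compound 3 by methoxy in place of chloro on an aromatic carbon. Among the compounds with values here, this change sits on the other ring, the 4-chlorophenyl attached to the shared core, where no measured step has yet been taken, so none of the three steps bears on it directly. Within the data shown here, the only comparable swap, chloro for hydroxy on the amine ring, stayed within the scatter, whereas chloro for trifluoromethyl did not.

Compound 4 is therefore expected to stay close to compound 3, with a step of a 1.1-fold higher number from compound 3 to compound 4 (0.05 log units; within the scatter), and an estimated 5000 nM, likely between 2000 nM and 15000 nM.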

Compound 4, half-maximal inhibitory concentration: 1980 nM
For compound 4 the middle estimate is 2.5-fold (0.40 log units) above the measured one; measured number below the stated range.
By their numbers in this assay, from the lowest: compounds 4, 1 and 3 (each within the scatter of the next, the first and the last beyond it). At a limit, above all of these: compound 2.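

Within the data shown here, the ring on the other side of the shared core, untouched by the earlier steps, turns out to matter in this assay: with the hydroxy group on the amine ring kept in place, going from 4-chlorophenyl to 4-methoxyphenyl gives a 2.2-fold lower number from compound 3 to compound 4 (0.35 log units; beyond the scatter), a modest change but a real one. Chloro is therefore not required at this place on an aromatic carbon, para to a large group, since methoxy, which unlike chloro counts as a hydrogen-bond acceptor, is accepted there and gives the lower number of this pair. The compounds shown give no measured reason for this shift.

As far as these compounds go, this is a single pair, so it remains open whether the same swap would have a similar effect with chloro or trifluoromethyl on the amine ring rather than hydroxy. Also open, from the compounds shown here alone, is how other groups would behave at this place, such as an amine, a carboxylic acid or a longer chain like ethoxy, and so whether the lower number belongs to methoxy alone.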